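The source may hold more compounds than are shown below. What is called first, only, known or untested is meant among the compounds shown, and "the series" means these compounds.

Compound 3 (`O=[N+]([O-])c1ccccc1CNc1cc(Br)cc2[nH]ncc12`) is the better of the two numbered compounds in an assay for inhibition of Indoleamine 2,3-dioxygenase 1 (Homo sapiens), with stated times of 10 min and 60 min; a lower number here means a stronger inhibitor, a higher number a weaker inhibitor: in this assay compound 3 gives 8040 nM. Its nearest neighbour is compound 2 (`O=[N+]([O-])c1ccc(Cl)cc1CNc1cc(C(F)(F)F)cc2[nH]ncc12`), which in this assay gives 37700 nM. Compound 1 (`COC(=O)c1cc(NCc2ccccc2[N+](=O)[O-])c2cn[nH]c2c1`) reaches only a limit of the assay, > 100000 nM, so that the limit of > 100000 nM in this assay, at which 1 of the 3 values shown sits, sets it apart from the two numbers. Among the measured compounds shown here, the one measured step at the same position, an at least 12-fold lower number from compound 1 to compound 3 (1.09 log units; beyond the scatter), shows that this position can move the read-out strongly.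

Compound 4 (`O=[N+]([O-])c1ccccc1CNc1cc(C(F)(F)F)cc2[nH]ncc12`) differs from compound 3 by trifluoromethyl in place of bromo on an aromatic carbon. For the measured compounds named here, no measured step describes the exchange of bromo for trifluoromethyl directly; what is known is that compound 2, which carries the trifluoromethyl, sits above compound 3, while compound 2 also differs from compound 4 in a chloro group on the other ring. A moderate rise is therefore expected, a 2.5-fold higher number from compound 3 to compound 4 (0.40 log units; beyond the scatter). Compound 4 is estimated at 20000 nM, with a range from 6000 nM to 60000 nM.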

Compound 4, half-maximal inhibitory concentration: 14000 nM
For compound 4 the middle estimate is 1.4-fold (0.15 log units) above the measured one, and the stated range covers the measured number.
By their numbers in this assay, from the lowest: compounds 3 and 4 (each within the scatter of the next); then compound 2. At a limit, above all of these: compound 1.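

In this assay, the exchange of bromo for trifluoromethyl gives a 1.7-fold higher number from compound 3 to compound 4 (0.24 log units; within the scatter), so on this aromatic carbon, para to a fused ring, the two groups cannot be told apart. Hydrogen in place of chloro gives a 2.7-fold lower number from compound 2 to compound 4 (0.43 log units; beyond the scatter), which ties the higher number of compound 2 to its chloro group and not to trifluoromethyl. Trifluoromethyl in place of methoxycarbonyl gives an at least 7.1-fold lower number from compound 1 to compound 4 (0.85 log units; beyond the scatter), so the gain seen with bromo recurs with a second group, although this step starts from a limit of the assay: the limit of > 100000 nM in this assay, at which 1 of the 4 values shown sits.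

The compounds shown leave open how a nitrile, an amine or a carboxylic acid on this carbon would read. They also leave open whether a plain hydrogen here would keep the number of compound 4 or lose it.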